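Removing one fluoro from compound 2: what to expect

The source may hold more compounds than are shown below. What is called first, only, known or untested is meant among the compounds shown, and "the series" means these compounds.

Compound 1 `CN(C(=O)NC(=O)c1cccc(C(F)(F)F)c1)c1nc(C(F)(F)F)c(C(=O)N/N=C/c2ccc(C(F)(F)F)cc2)s1` and compound 2 `CN(C(=O)NC(=O)c1c(F)cccc1F)c1nc(C(F)(F)F)c(C(=O)N/N=C/c2ccc(C(F)(F)F)cc2)s1` share one core and differ only in the aromatic ring attached to a carbonyl carbon. In a functional assay on HepG2 cells (Homo sapiens) for inhibition, read by MTT assay, with a stated time of 72 h (on this read-out higher numbers stand for weaker inhibition and lower numbers for stronger inhibition), compound 1 gives 7.71 ug/mL, while compound 2 gives 49.6 ug/mL, and a 6.4-fold higher number from compound 1 to compound 2 (0.81 log units; beyond the scatter). On the two numbers shown, compound 2 is thus the weaker inhibitor of the pair.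

Compound 3 `CN(C(=O)NC(=O)c1ccccc1F)c1nc(C(F)(F)F)c(C(=O)N/N=C/c2ccc(C(F)(F)F)cc2)s1` takes one further step from compound 2: hydrogen in place of fluoro on an aromatic carbon. Among the measured compounds shown here, no measured step concerns this particular change; the only step in hand swaps the whole ring for another, and that says little about losing a single fluoro. The expectation for compound 3 is therefore a step of a 1.4-fold lower number from compound 2 to compound 3 (0.15 log units; within the scatter), most likely no change beyond the scatter, in this assay. Compound 3 is accordingly estimated at 35 ug/mL, with a range from 12 ug/mL to 100 ug/mL.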

Compound 3, half-maximal inhibitory concentration: 4.56 ug/mL
Beside the measured number, compound 3's estimate is 7.7-fold (0.89 log units) above it; measured number outside the range, below it.
By their numbers in this assay, from the lowest: compounds 3 and 1 (each within the scatter of the next); then compound 2.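

The step of an 11-fold lower number from compound 2 to compound 3 (1.04 log units; beyond the scatter) shows that in this assay a single fluoro on this ring can make a large difference: one heavy atom leaves, and the number moves well beyond the scatter. A whole-ring swap is therefore not needed for a large move, and the step of a 1.7-fold lower number from compound 1 to compound 3 (0.23 log units; within the scatter), within the scatter, leaves the 2-fluorophenyl and 3-(trifluoromethyl)phenyl rings not told apart, with compound 2 alone standing apart among the three. Nothing available bears on what lies behind the large step.

The compounds shown leave open how a plain phenyl ring, carrying no fluoro at all, would read in this assay. From the compounds shown here alone, it is also open whether a chloro or methoxy group in place of the fluoro that left would behave like hydrogen or like fluoro.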